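This account rests on a few compounds, and the source may have more. Where it says the series, first, only, none or still open, it means among the compounds named here.

Measured in a functional assay on HeLa cells (Homo sapiens) for inhibition, read by MTT assay, with a stated time of 72 h; on this read-out higher numbers stand for weaker inhibition and lower numbers for stronger inhibition:
- compound 1 `Nc1ncnc2c1c(-c1cnc3[nH]ccc3c1)nn2CCCCCCCCC(=O)NO`: 7470 nM
- compound 2 `Nc1ncnc2c1c(-c1cnc3[nH]ccc3c1)nn2CCCCC(=O)NO`: > 150000 nM (a limit, not a number)
- compound 3 `Nc1ncnc2c1c(-c1cnc3[nH]ccc3c1)nn2CCCCCC(=O)NO`: > 150000 nM (a limit, not a number)

Compound 3 stands at the limit of > 150000 nM in this assay, at which 2 of the 3 values shown sit. On these data alone, this is a limit and not a number, so the true starting point of the step is unknown.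

Compound 4 `Nc1ncnc2c1c(-c1cnc3[nH]ccc3c1)nn2CCCCCCCCCC(=O)NO` carries 4-(hydroxycarbamoyl)butyl in place of hydroxycarbamoyl on a saturated chain carbon, five bonds along the chain from an aromatic nitrogen, so the chain grows: 4-(hydroxycarbamoyl)butyl in place of hydroxycarbamoyl on a saturated chain carbon, five bonds along the chain from an aromatic nitrogen.

The closest measured evidence is the same exchange run in reverse, four bonds along the chain from an aromatic nitrogen: an at least 20-fold higher number from compound 1 to compound 2 (1.30 log units; beyond the scatter). The other step that bears on it, an at least 20-fold higher number from compound 1 to compound 3 (1.30 log units; beyond the scatter), is also large. Both steps shorten the chain and end at a limit. The step that the two limits leave unreadable from compound 2 to compound 3 cannot be read, so it adds nothing. Read backwards, the two large steps suggest that lengthening the chain should bring the number down, which means stronger inhibition. This pattern rests on three compounds only, and none of them goes against it.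

The expected change is large: an at least 16-fold lower number from compound 3 to compound 4 (1.22 log units; beyond the scatter). For compound 4 the estimated value in this assay is 9000 nM, with an expected range of 2500 nM to 35000 nM.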

Compound 4, half-maximal inhibitory concentration: 7560 nM
Compound 4: middle estimate off by 1.2-fold (0.08 log units), on the high side, and the stated range covers the measured number.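

In this assay, compound 4 confirms that a long chain matters, since it stands well clear of both short-chain compounds: an at least 19-fold lower number from compound 3 to compound 4 (1.29 log units; beyond the scatter) and an at least 19-fold lower number from compound 2 to compound 4 (1.29 log units; beyond the scatter). Among these compounds, compound 1 was the only long-chain example until now, and the new result also shows that going from hydroxycarbamoyl to (hydroxycarbamoyl)methyl at the end of a long chain makes no readable difference, with a 1.0-fold higher number from compound 1 to compound 4 (0.01 log units; within the scatter). The exchange of hydroxycarbamoyl and 4-(hydroxycarbamoyl)butyl has now been seen as a large step twice, although its true size remains unknown: the same change on two cores in this assay, an at least 20-fold higher number (1.30 log units; beyond the scatter) from compound 1 to compound 2 and an at least 19-fold higher number (1.29 log units; beyond the scatter) from compound 4 to compound 3; the limit leaves it open whether they differ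

On these data alone, the short-chain compounds give only limits, not numbers, so the step from compound 2 to compound 3 cannot be read and nothing shows how far below the limit their inhibition lies: the limit of > 150000 nM in this assay, at which 2 of the 4 values shown sit. Still open are how a chain shorter than in compound 1 but longer than in compound 3 would behave, whether a still longer chain than in compound 4 would change the number, and whether a carboxylic acid could take the place of the hydroxycarbamoyl group.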